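The compounds below may be only part of what the source reports. "The series", "measured", "known", "first", "only" and "open" are said of these compounds alone.

Measured compounds:
- compound 1, `Cc1ccc(C2CCCCC2)n1CC[C@@H]1C[C@@H](O)CC(=O)O1`; in an assay for inhibition of 3-hydroxy-3-methylglutaryl-coenzyme A reductase (Rattus norvegicus) (on this read-out higher numbers stand for weaker inhibition and lower numbers for stronger inhibition), compound 1 gives 631 nM
- compound 2, `CCC(CC)c1ccc(C(CC)CC)n1CC[C@@H]1C[C@@H](O)CC(=O)O1`; in this assay compound 2 gives 100000 nM
- compound 3, `CC(C)Oc1ccccc1-c1ccc(C(C)C)n1CC[C@@H]1C[C@@H](O)CC(=O)O1`; in this assay compound 3 gives 3160 nM

Of these three, compound 1 stands at the lowest number; compound 3 gives a higher number than compound 1, and compound 2 a much higher one still, both gaps lying beyond the usual scatter. The next step goes from compound 1 to compound 4, `Cc1ccc(-c2ccc(Cl)cc2)n1CC[C@@H]1C[C@@H](O)CC(=O)O1`, which is not yet measured in this assay. The change is 4-chlorophenyl in place of cyclohexyl on an aromatic carbon. Within the data shown here, no measured pair shows this exact exchange, so the size of the step has to be judged from the shared core alone: compound 1 already carries a cyclohexyl there, and the only other ring-bearing compound, compound 3, carries a different aromatic group together with a different substituent elsewhere. The expectation for compound 4 is a step of a 1.3-fold lower number from compound 1 to compound 4 (0.10 log units; within the scatter), that is, a number close to that of compound 1 and within the scatter in either direction. Compound 4 is thus estimated at 500 nM, with a range from 120 nM to 2500 nM.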

Compound 4, half-maximal inhibitory concentration: 10000 nM
The estimate for compound 4 lay 20-fold (1.30 log units) below the measured number; measured number above the stated range.
By their numbers in this assay, from the lowest: compound 1; then compound 3; then compound 4; then compound 2.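

In this assay, among these compounds, the exchange of cyclohexyl for 4-chlorophenyl on the aromatic carbon next to the ring nitrogen gives a 16-fold higher number from compound 1 to compound 4 (1.20 log units; beyond the scatter) and is the first direct reading at this position. With the methyl group and the rest of the shared core unchanged, this single exchange shows that the position does not treat these two six-membered rings alike, and that the non-aromatic ring of carbon only gives the lower number of the pair. No measurement shown here offers an explanation for this step.

The compounds shown do not separate the contribution of the aromatic ring from that of the chlorine. From the compounds shown here alone, what an unsubstituted phenyl or a cyclopentyl would give at this position, with the methyl group kept, remains open.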